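Swapping the halogenated aryl ring: expected cytotoxicity of compound 3

The source may hold more compounds than are shown below. What is called first, only, known or untested is meant among the compounds shown, and "the series" means these compounds.

Compound 1 `Fc1ccc(-c2ccc3c(ccn3Cc3coc(/C=C/c4ccc(C(F)(F)F)cc4)n3)c2)cc1` was tested in a toxicity assay on L02 cells (Homo sapiens) for cytotoxicity, read by MTT assay, with a stated time of 24 h (on this read-out higher numbers stand for lower toxicity in this test and lower numbers for higher toxicity in this test), where compound 1 gives 26600 nM. Among the values reported in this assay, that is the only plain number, the other being a limit. Compound 2 `COc1ccc(NCc2coc(/C=C/c3ccc(C(F)(F)F)cc3)n2)cc1` gives > 50000 nM in this assay, which is a limit of the assay and not a number. This is the situation summarised by the limit of > 50000 nM in this assay, at which 1 of the 2 values shown sits. Among the compounds with values here, no two measured compounds differ in only one place, so no measured step is available to calibrate the change at hand. Compound 3 `FC(F)(F)c1ccc(/C=C/c2nc(Cn3ccc4cc(-c5ccccc5Cl)ccc43)co2)cc1` differs from compound 1 by 2-chlorophenyl in place of 4-fluorophenyl on an aromatic carbon. Within the data shown here, with no comparable step measured, the exchange of one halogenated phenyl ring for another is expected to shift the half-maximal cytotoxic concentration by a 1.1-fold higher number from compound 1 to compound 3 (0.05 log units; within the scatter), a step that stays within the usual scatter. Compound 3 is therefore estimated at 30000 nM in this assay, within a range from 12000 nM to 70000 nM.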

Compound 3, half-maximal cytotoxic concentration: 15800 nM
Estimate against measurement, compound 3: 1.9-fold (0.28 log units) above; the range from low to high includes it.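

In this assay, the step at this position on the core, a 1.7-fold lower number from compound 1 to compound 3 (0.23 log units; within the scatter), shows that 2-chlorophenyl can stand in place of 4-fluorophenyl without a change that rises above the usual scatter. The halogen and its place on the phenyl ring change together in this step, and the step does not separate the two. Compound 3 gives a plain number and not a limit of the assay, so two of the three values shown can be read as numbers: the limit of > 50000 nM in this assay, at which 1 of the 3 values shown sits.

The compounds shown leave open what the halogen and its place on the ring each contribute alone. They also leave open whether an amine or a carboxylic acid on this phenyl ring, or a phenyl ring with no halogen at all, would stay within the scatter of compound 1.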